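The source may hold more compounds than are shown below. What is called first, only, known or untested is meant among the compounds shown, and "the series" means these compounds.

In a functional assay on HeLa cells (Homo sapiens) for cytotoxicity, read by MTT assay, with a stated time of 48 h (a lower number here means a stronger inhibitor, a higher number a weaker inhibitor), compound 1 (`O=C(O)CN1C(=O)/C(=C/c2nc3ccccc3n2Cc2ccc(F)cc2)SC1=S`) gives 13900 nM. Compound 2 (`O=C(O)CN1C(=O)/C(=C/c2nc3ccccc3n2Cc2cccc(F)c2)SC1=S`) gives > 50000 nM, which is a limit and not a number. Compound 3 (`COc1cc(Cn2c(/C=C3\SC(=S)N(CC(=O)O)C3=O)nc3ccccc32)cc(OC)c1`) differs from compound 2 in one place: 3,5-dimethoxyphenyl in place of 3-fluorophenyl on a saturated chain carbon bound to an aromatic nitrogen. This puts 3,5-dimethoxyphenyl in place of 3-fluorophenyl on a saturated chain carbon bound to an aromatic nitrogen. Going by the values given here, the only measured step at this place is an at least 3.5-fold higher number from compound 1 to compound 2 (0.55 log units; beyond the scatter), beyond the scatter, so this assay does respond to a change on this group. Among the compounds with values here, no measured compound carries a 3,5-dimethoxyphenyl group, and the direction is only weakly fixed. A modest step toward a lower number is expected, and another limit reading remains quite possible. The estimated change is an at least 1.6-fold lower number from compound 2 to compound 3 (0.22 log units; that floor lies within the scatter). For compound 3 the expected value is 30000 nM, with an estimated range from 10000 nM to 60000 nM.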

Compound 3, half-maximal inhibitory concentration: 17700 nM
Estimate against measurement, compound 3: 1.7-fold (0.23 log units) above; measured number inside the range.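

In this assay, going by these compounds alone, the earlier compounds showed this position moving in one direction only; 3,5-dimethoxyphenyl in place of 3-fluorophenyl now gives an at least 2.8-fold lower number from compound 2 to compound 3 (0.45 log units; beyond the scatter), so the reading can also move back toward a lower number. Against 4-fluorophenyl, the same group gives a 1.3-fold higher number from compound 1 to compound 3 (0.10 log units; within the scatter), so among these three compounds a fluorine on the phenyl ring is not needed for a reading in the range of compound 1. The first of these steps is only a floor, because compound 2 stands at a limit: the limit of > 50000 nM in this assay, at which 1 of the 3 values shown sits.

Going by these compounds, how far the true reading of compound 2 lies from that limit remains open. Also open, on these data alone, is how an unsubstituted phenyl, a single methoxy group, an amine on the ring or a longer chain would read at this place.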